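Swapping a hydroxyphenyl group for iodine on the shared core

A few compounds are considered here, and "the series" means these few. Any claim that something is new, unique, unknown or untested is made for them only; others in the source may bear on it.

The study measures cytotoxicity toward human cells in an ADME assay on HEL cells (Homo sapiens) for cytotoxicity, with a stated time of 3 days; on this read-out higher numbers stand for lower toxicity in this test and lower numbers for higher toxicity in this test. Of the compounds shown here, two have numbers so far. Compound 1 `Cc1cc(-c2ccc(O)cc2)c2ncc(CSCCc3ccccc3)n2c1` gives 20 ug/mL in this assay, the highest of the two numbers, which means the lowest toxicity seen in this set. Compound 2 `c1ccc(CCSCc2cnc3ccc(-c4ccccc4)cn23)cc1` gives 4 ug/mL in this assay, and the gap between the two lies beyond the usual scatter, so compound 1 is plainly the less toxic of the pair.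

Compound 3 `Cc1cc(I)c2ncc(CSCCc3ccccc3)n2c1` has not yet been measured. It keeps the core of compound 1 and differs in one place: iodo in place of 4-hydroxyphenyl on an aromatic carbon. Among the measured compounds shown here, nothing among the measured compounds tracks this particular swap, so there is no directly comparable step to lean on.

The account therefore rests on the two numbers alone. Compound 3 is expected to land somewhat lower than compound 1, a step of a 2.0-fold lower number from compound 1 to compound 3 (0.30 log units; within the scatter), since compound 1 with 20 ug/mL is the only related anchor and a modest drop seems the more likely direction. For compound 3 the estimated minimum cytotoxic concentration is 10 ug/mL, with a plausible range from 4 ug/mL to 40 ug/mL.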

Compound 3, minimum cytotoxic concentration: >= 4 ug/mL
Compound 3: only a limit was reported (the forecaster's own chance of this, stated with the estimate: 20%); the middle value is on the limit's open side.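

In this assay compound 3 gives >= 4 ug/mL, which is a limit and not a number. Among the compounds shown here, no step from compound 1 to compound 3 can be read because the result for compound 3 is only this limit: the limit of >= 4 ug/mL in this assay, at which 1 of the 3 values shown sits. The compounds shown leave open whether iodo in place of 4-hydroxyphenyl raises, lowers or leaves unchanged the minimum cytotoxic concentration.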